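A few compounds are considered here, and "the series" means these few. Any claim that something is new, unique, unknown or untested is made for them only; others in the source may bear on it.

Three compounds share one core, a urea attached to a cyclopentane bearing an aryl group, and were tested in an assay on microsomes for inhibition of acyl-CoA:cholesterol acyltransferase (Oryctolagus cuniculus); a lower number here means a stronger inhibitor, a higher number a weaker inhibitor. Compound 1 `Cc1ccc(C2(CNC(=O)Nc3c(C(C)C)cccc3C(C)C)CCCC2)cc1` gives 25 nM. Compound 2 `CC(C)c1cccc(C(C)C)c1NC(=O)NCC1(c2ccc(C(F)(F)F)cc2)CCCC1` gives 66 nM, and compound 3 `CC(C)c1cccc(C(C)C)c1NC(=O)NCC1(c2cccc([N+](=O)[O-])c2)CCCC1` gives 51 nM. On these numbers compound 3 stands second highest of the three, next to compound 2 and furthest from compound 1.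

Compound 4 `CC(C)c1cccc(C(C)C)c1NC(=O)NCC1(c2ccc([N+](=O)[O-])cc2)CCCC1` keeps every atom of compound 3 but joins them differently: 4-nitrophenyl in place of 3-nitrophenyl on a saturated ring carbon. Among the compounds with values here, no measured pair tests exactly this move of the nitro group. The nearest guides are a 2.0-fold higher number from compound 1 to compound 3 (0.31 log units; beyond the scatter), a 2.6-fold higher number from compound 1 to compound 2 (0.42 log units; beyond the scatter) and a 1.3-fold lower number from compound 2 to compound 3 (0.11 log units; within the scatter), all modest or within the scatter, so swapping one aryl group for another on this carbon has so far moved this assay only a little. A similar small step is therefore expected, with no firm direction.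

Compound 4 is expected to give about 45 nM, between 20 nM and 110 nM, meaning an estimated step of a 1.1-fold lower number from compound 3 to compound 4 (0.05 log units; within the scatter).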

Compound 4, half-maximal inhibitory concentration: 131 nM
For compound 4 the middle estimate is 2.9-fold (0.46 log units) below the measured one; the whole stated range lies below it.
By their numbers in this assay, from the lowest: compound 1; then compounds 3, 2 and 4 (each within the scatter of the next, the first and the last beyond it).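

Moving the nitro group, with no atom gained or lost, is enough to shift this assay (a 2.6-fold higher number from compound 3 to compound 4 (0.41 log units; beyond the scatter)), so at this aromatic ring the place of a group counts as well as its identity. In the 4-substituted compounds, the change of group gives a clear step for nitro in place of methyl (a 5.2-fold higher number from compound 1 to compound 4 (0.72 log units; beyond the scatter)), the largest seen so far, but not for nitro in place of trifluoromethyl (a 2.0-fold higher number from compound 2 to compound 4 (0.30 log units; within the scatter)), so these last two compounds cannot be told apart here. Nothing measured in this set accounts for the effect of moving the nitro group.

As far as these compounds go, only the nitro group appears here in both placements, so whether methyl or trifluoromethyl would respond to the same move remains open. From the compounds shown here alone, how an amine or a carboxylic acid in place of the nitro group would read in this assay is also open.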